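Cyclopropyl for Methyl in a Urea Series

The source may report more compounds than this note shows. Statements on the series, on what has been measured and on what is new or still open speak of the compounds shown alone.

Measured compounds:
compound 1 `CC(C)(C)c1cc(NC(=O)Nc2ccc(-c3cn4cc(F)ccc4n3)cc2)no1`, 20.9 nM
compound 2 `Cc1ccc2nc(-c3ccc(NC(=O)Nc4cc(C(C)(C)C)on4)cc3)cn2c1`, 4.08 nM

Both compounds were tested in a functional assay on MV4-11 cells (Homo sapiens) for cytotoxicity, read by MTT assay, with a stated time of 72 h; on this read-out lower numbers stand for stronger inhibition and higher numbers for weaker inhibition. Within the data shown here, compound 2 gives the lower of the two numbers, and its only neighbour, compound 1, stands a 5.1-fold lower number from compound 1 to compound 2 (0.71 log units; beyond the scatter) away, so the gap between them is real rather than noise.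

Compound 3 `CC(C)(C)c1cc(NC(=O)Nc2ccc(-c3cn4cc(C5CC5)ccc4n3)cc2)no1` is the next step from compound 2. The change is cyclopropyl in place of methyl on an aromatic carbon. Among the measured compounds shown here, no measured pair in this set shows a methyl turned into a cyclopropyl, so there is no direct precedent. For the measured compounds named here, the one measured step, a 5.1-fold lower number from compound 1 to compound 2 (0.71 log units; beyond the scatter), shows that this position does respond to what sits on it, but it compares fluoro with methyl, not methyl with a larger carbon ring. The expectation therefore rests on compound 2 alone as a starting point, with a wide band around it.

Compound 3 is estimated to give 4.5 nM in this assay, with a range from 1.5 nM to 14 nM. This corresponds to an expected step of a 1.1-fold higher number from compound 2 to compound 3 (0.04 log units; within the scatter), a change that may well fall within the scatter.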

Compound 3, half-maximal inhibitory concentration: 15.8 nM
Estimate against measurement, compound 3: 3.5-fold (0.55 log units) below, and the stated range ends below it.
By their numbers in this assay, from the lowest: compound 2; then compounds 3 and 1 (each within the scatter of the next).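

Read in this assay, this position now carries three different groups, and the result shows that adding carbon here does not keep the gain seen with methyl: the step is a 3.9-fold higher number from compound 2 to compound 3 (0.59 log units; beyond the scatter) and lies beyond the scatter. Replacing the fluoro group with cyclopropyl gives a 1.3-fold lower number from compound 1 to compound 3 (0.12 log units; within the scatter) and stays within the scatter, so these two compounds cannot be told apart in this assay, while compound 2, with its methyl, stands clear of both. The earlier pair could suggest only that methyl does better than fluoro, but this third compound shows that a carbon substituent alone does not bring the lower number, and nothing available here explains why.

The compounds shown leave open whether the low number belongs to methyl alone or would survive a small step up to ethyl, which would sit on the same aromatic carbon with one more carbon and no ring. They also leave open how a methoxy group or an amine at this position would compare with methyl, since every group so far is either fluoro or carbon only.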